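Carboxymethyl in place of oxolan-2-yl on the chain carbon

The source may hold more compounds than are shown below. What is called first, only, known or untested is meant among the compounds shown, and "the series" means these compounds.

Three measured compounds share one core and differ only on a saturated chain carbon bound to an aromatic nitrogen. Going by the values given here, in a functional assay on FaDu cells (Homo sapiens) for cytotoxicity, read by MTT assay, with a stated time of 72 h (on this read-out lower numbers stand for higher toxicity in this test and higher numbers for lower toxicity in this test), compound 3 `COc1ccc(NC(=O)C(=O)c2cn(CC3CCCO3)c3ccccc23)cn1` gives 31 nM, the lowest of the two numbers known. Compound 1 `COC(=O)CCn1cc(C(=O)C(=O)Nc2ccc(OC)nc2)c2ccccc21` gives 168 nM. Compound 2 `COc1ccc(NC(=O)C(=O)c2cn(CC(C)(C)OC)c3ccccc23)cn1` reaches only a limit, > 10000 nM, which is the limit of > 10000 nM in this assay, at which 1 of the 3 values shown sits. The measured steps are a 5.4-fold lower number from compound 1 to compound 3 (0.73 log units; beyond the scatter), an at least 59-fold higher number from compound 1 to compound 2 (1.77 log units; beyond the scatter) and an at least 320-fold lower number from compound 2 to compound 3 (2.50 log units; beyond the scatter). Compound 4 `COc1ccc(NC(=O)C(=O)c2cn(CCC(=O)O)c3ccccc23)cn1` is not yet measured and differs from compound 3 by carboxymethyl in place of oxolan-2-yl on a saturated chain carbon bound to an aromatic nitrogen. Its chain is closest to that of compound 1, which stands well above compound 3, so a higher number in this assay is expected, with the size uncertain. Compound 4 is therefore estimated at 1500 nM, within 200 nM to 10000 nM. The expected step is a 48-fold higher number from compound 3 to compound 4 (1.68 log units; beyond the scatter).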

Compound 4, concentration lethal to 50% of the cells: > 10000 nM
Compound 4: only a limit was reported; the forecaster's own chance of this, stated with the estimate: 25%; middle value at least 6.6-fold (0.82 log units) from the limit.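

Hydrogen in place of methyl on an oxygen next to a carbonyl group gives an at least 59-fold higher number from compound 1 to compound 4 (1.77 log units; beyond the scatter), so in this assay this one small change at the end of the chain is enough to lose the effect of compound 1. Carboxymethyl in place of oxolan-2-yl gives an at least 320-fold higher number from compound 3 to compound 4 (2.50 log units; beyond the scatter), which makes the chain of compound 4 the second at this position to fall far short of compound 3. Compound 4 reaches only a limit, as does compound 2, and the step between these two cannot be read: the limit of > 10000 nM in this assay, at which 2 of the 4 values shown sit.

The compounds shown leave open how an amine or a primary amide in place of carboxymethyl would read in this assay. They also leave open whether a longer chain ending in a carboxylic acid would read differently.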